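Amide Chain Shortening on a Sulfonate Ester Scaffold

This account rests on a few compounds, and the source may have more. Where it says the series, first, only, none or still open, it means among the compounds named here.

Measured compounds:
compound 1, `CCCCCC(=O)Nc1cccc(S(=O)(=O)Oc2ccccc2C(C)C)c1`: 12000 nM
compound 2, `CC(C)C(=O)Nc1cccc(S(=O)(=O)Oc2ccccc2C(C)C)c1`: 13000 nM
compound 3, `CCCCCC(=O)Nc1ccc(S(=O)(=O)Oc2ccccc2C(C)C)cc1`: 5300 nM

In a functional assay on MCF7 cells (Homo sapiens) for antiproliferative activity, read by sulforhodamine B assay, with a stated time of 48 h (a higher number here means a weaker inhibitor, a lower number a stronger inhibitor), compound 1 gives 12000 nM and compound 2 gives 13000 nM. The change between them is isopropyl in place of pentyl on a carbonyl carbon, and it made a 1.1-fold higher number from compound 1 to compound 2 (0.03 log units; within the scatter). Compound 3 gives 5300 nM in this assay, the lowest of the three numbers; its difference from compound 1 lies in the core, and the difference between the two cores is not broken down here.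

Compound 4, `CC(C)C(=O)Nc1ccc(S(=O)(=O)Oc2ccccc2C(C)C)cc1`, is not yet measured. It is made from compound 3 by isopropyl in place of pentyl on a carbonyl carbon, the same change as from compound 1 to compound 2, at the same place. Because that change made a 1.1-fold higher number from compound 1 to compound 2 (0.03 log units; within the scatter), the step from compound 3 to compound 4 is expected to be of similar size, a 1.1-fold higher number from compound 3 to compound 4 (0.04 log units; within the scatter), staying close to compound 3. Compound 4 is therefore estimated at 5800 nM in this assay. The range for compound 4 is expected to run from 3000 nM to 11000 nM.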

Compound 4, half-maximal inhibitory concentration: 8600 nM
Beside the measured number, compound 4's estimate is 1.5-fold (0.17 log units) below it, and the stated range covers the measured number.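

Carried to the second core in this assay, isopropyl in place of pentyl on a carbonyl carbon gave a 1.6-fold higher number from compound 3 to compound 4 (0.21 log units; within the scatter). Set beside the earlier step, this gives no sign that the outcome of the change depends on which of the two cores carries it: the same change on two cores in this assay, a 1.1-fold higher number (0.03 log units; within the scatter) from compound 1 to compound 2 and a 1.6-fold higher number (0.21 log units; within the scatter) from compound 3 to compound 4, 1.5-fold (0.18 log units) apart, within the scatter of two such steps. Within the data shown here, this shows that swapping pentyl for isopropyl left the number within the scatter on both cores, but it covers only this one pair of groups, two cores and a single assay, so it does not show that the change would behave the same way on any other core, or that the two steps are truly identical.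

The compounds shown leave open whether a chain longer than pentyl, or a chain ending in an amine or a carboxylic acid, would move the number beyond the scatter on either core. They also leave open whether methyl in place of pentyl on that carbonyl carbon would behave as isopropyl does here.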